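The source may report more compounds than this note shows. Statements on the series, on what has been measured and on what is new or still open speak of the compounds shown alone.

Measured so far:

Compound 1: `O=C(/C(=C\c1ccccc1F)S(=O)(=O)c1ccc(Br)cc1)c1ccc(Cl)cc1` — 25000 nM
Compound 2: `Cc1ccc(S(=O)(=O)/C(=C/c2ccccc2F)C(=O)c2ccc(Cl)cc2)cc1` — 2500 nM
Compound 3: `O=C(/C(=C\c1ccc(F)c([N+](=O)[O-])c1)S(=O)(=O)c1ccc(Br)cc1)c1ccc(Br)cc1` — 25000 nM

All three were tested in a functional assay on DU-145 cells (Homo sapiens) for inhibition, read by trypan blue exclusion, with a stated time of 96 h; on this read-out higher numbers stand for weaker inhibition of growth and lower numbers for stronger inhibition of growth. Compound 2 gives the lowest number of the three, and its distance to each of the others is beyond the scatter. For the measured compounds named here, the one single-point change among the measured compounds is a 10-fold lower number from compound 1 to compound 2 (1.00 log units; beyond the scatter), which shows that a small swap on one of the aromatic rings can move the number a good deal. Compound 3 differs from compound 1 in two places at once, and the two give the same number, so those two changes together left the read-out where it was.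

Compound 4, `Cc1ccc(S(=O)(=O)/C(=C/c2ccc(N(C)C)cc2)C(=O)c2ccc(Cl)cc2)cc1`, has not yet been measured. It differs from compound 2 in one place: 4-(dimethylamino)phenyl in place of 2-fluorophenyl on a double-bonded chain carbon bound to a double-bonded chain carbon. Going by the values given here, no measured pair changes this part of the molecule, so nothing among the steps bears directly on it. Among the compounds with values here, the only step on record concerns a different ring, and the two-place difference between compound 1 and compound 3 gives no guide either. Within the data shown here, with no bearing step, the expectation for compound 4 in this assay is a number near that of compound 2, with a wide range: 2500 nM, between 600 nM and 10000 nM, which is expected to amount to no change at the digits printed from compound 2 to compound 4 (within the scatter).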

Compound 4, concentration for 50% growth inhibition: > 100000 nM
Compound 4: only a limit was reported; the forecaster's own chance of this, stated with the estimate: 10%; middle value at least 40-fold (1.60 log units) from the limit.
By their numbers in this assay, from the lowest: compound 2; then compounds 1 and 3 (each within the scatter of the next). At a limit, above all of these: compound 4.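

The group on the double-bonded chain carbon bound to a double-bonded chain carbon proves to matter a great deal in this assay: an at least 40-fold higher number from compound 2 to compound 4 (1.60 log units; beyond the scatter). For the compounds shown here, the only earlier single-place change concerned a different ring, and it gave a smaller, though still clear, step: a 10-fold lower number from compound 1 to compound 2 (1.00 log units; beyond the scatter). The reading for compound 4 is a limit and not a number, so the step gives only a minimum size, and the real gap to compound 2 stays unknown: the limit of > 100000 nM in this assay, at which 1 of the 4 values shown sits.

This single pair shows that the position is not indifferent to what sits there, and that swapping 2-fluorophenyl for 4-(dimethylamino)phenyl goes toward weaker inhibition of growth. Still, the pair takes one group away and puts another in its place, so it cannot tell whether the change in the read-out goes with the arrival of the dimethylamino group or with the departure of the fluorine. A plain phenyl at this place, or a ring carrying a methoxy group or a primary amine, would be needed to separate those two readings and to show how far the trend extends.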